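The compounds below may be only part of what the source reports. "The series", "measured", "known", "first", "only" and "open" are said of these compounds alone.

The set comprises four compounds built on two cores. Compound 1 `CCCC1(C)SC(NC2CCCCCCC2)=NC1=O` and compound 3 `CCC1(C)SC(NC2CCCCCCC2)=NC1=O` share one core, while compound 2 `CCCC1(C)SC(NC23CCC(CC2)C3)=NC1=O` and compound 4 `CCC1(C)SC(NC23CCC(CC2)C3)=NC1=O` share the other; how the two cores differ is not broken down here. All four belong to one study in an assay on HEK293 cells for binding affinity to 11-beta-hydroxysteroid dehydrogenase type 2 (Homo sapiens), read by scintillation proximity assay; a lower number here means a stronger inhibitor, a higher number a weaker inhibitor.

In this assay compound 1 gives only a limit, > 10000 nM. Compound 3 also gives only a limit, > 10000 nM. For compound 2 the record in this assay reads "not determined" (no result reported). Compound 4 has not yet been measured.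

The change from compound 1 to compound 3 is small, a methyl leaving and a hydrogen entering (hydrogen in place of methyl on a saturated chain carbon, two bonds along the chain from a saturated ring carbon). In this assay the step it made is a step that the two limits leave unreadable from compound 1 to compound 3, because of the limit of > 10000 nM in this assay, at which 2 of the 3 values shown sit. Exactly the same change, at the same place, carries compound 2 to compound 4 (hydrogen in place of methyl on a saturated chain carbon, two bonds along the chain from a saturated ring carbon); across the four compounds it occurs twice.

Among the measured compounds shown here, with compound 2 lacking a number and the one measured instance of the change unreadable, the expectation for compound 4 rests on the two measured compounds of the other core sitting at the limit of > 10000 nM in this assay, at which 2 of the 3 values shown sit. Compound 4 is expected to give roughly 15000 nM in this assay, most likely again as a limit rather than a number, with an estimated range from 4000 nM to 60000 nM.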

Compound 4, half-maximal inhibitory concentration: > 10000 nM
Compound 4: a limit, no number (the forecaster's own chance of this, stated with the estimate: 75%); the middle value is on the limit's open side.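

In this assay compound 4 gives > 10000 nM, which is a limit and not a number. The record for compound 2 holds no number either, so no new step can be read from compound 2 to compound 4, because the values shown stop here: the limit of > 10000 nM in this assay, at which 3 of the 4 values shown sit.

The compounds shown leave open how strongly any of the four inhibits and whether hydrogen in place of methyl shifts that strength.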